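A few compounds are considered here, and "the series" means these few. Any claim that something is new, unique, unknown or untested is made for them only; others in the source may bear on it.

Working notes on the acyl variation at the carbonyl carbon of the shared core. In an assay on HEK293 cells for positive allosteric modulation of metabotropic glutamate receptor 5 (Homo sapiens), read by FLIPR, with a stated time of 1 h (on this read-out higher numbers stand for an effect only at larger amounts of compound and lower numbers for an effect already at smaller amounts), compound 1 `O=C(C1CCC1)N1CCc2nc(C#Cc3ccccc3)sc2C1` gives only a limit, > 10000 nM, not a number. Compound 2 `O=C(C1CCCC1)N1CCc2nc(C#Cc3ccccc3)sc2C1` gives 19 nM in this assay, and compound 3 `O=C(C1CCCO1)N1CCc2nc(C#Cc3ccccc3)sc2C1` gives 790 nM. Of the two numbers shown, compound 3 stands highest; its nearest neighbour is compound 2, with a 42-fold higher number from compound 2 to compound 3 (1.62 log units; beyond the scatter). The remaining steps, an at least 520-fold lower number from compound 1 to compound 2 (2.72 log units; beyond the scatter) and an at least 12-fold lower number from compound 1 to compound 3 (1.10 log units; beyond the scatter), rest on (the limit of > 10000 nM in this assay, at which 1 of the 3 values shown sits).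

Compound 4 `O=C(C1CCC(F)(F)CC1)N1CCc2nc(C#Cc3ccccc3)sc2C1` is not yet measured. Its change from compound 3 is 4,4-difluorocyclohexyl in place of oxolan-2-yl on a carbonyl carbon. Within the data shown here, two measured steps bear on it: enlarging a small carbocycle gave an at least 520-fold lower number from compound 1 to compound 2 (2.72 log units; beyond the scatter), while exchanging the carbocycle for the oxolan-2-yl gave a 42-fold higher number from compound 2 to compound 3 (1.62 log units; beyond the scatter). Returning to an all-carbon ring, now six-membered and carrying two fluorines, is therefore expected to lower the number by a large step, a 26-fold lower number from compound 3 to compound 4 (1.42 log units; beyond the scatter). Compound 4 is estimated at 30 nM, within a range from 8 nM to 150 nM.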

Compound 4, half-maximal effective concentration: 70 nM
Compound 4: the middle estimate sits 2.3-fold (0.37 log units) below what was measured, and the stated range covers the measured number.
By their numbers in this assay, from the lowest: compound 2; then compound 4; then compound 3. At a limit, above all of these: compound 1.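

With an 11-fold lower number from compound 3 to compound 4 (1.05 log units; beyond the scatter), low numbers at this carbonyl carbon are shown not to be confined to cyclopentyl: the six-membered all-carbon ring of 4,4-difluorocyclohexyl also gives one, well clear of the oxolan-2-yl. The change from cyclopentyl costs much less than the change to oxolan-2-yl did, at a 3.7-fold higher number from compound 2 to compound 4 (0.57 log units; beyond the scatter), so the acyl position accepts more than one ring size, while cyclopentyl still holds the lowest number. Against cyclobutyl the reading is an at least 140-fold lower number from compound 1 to compound 4 (2.15 log units; beyond the scatter), and this step gives only a bound, resting on a limit: the limit of > 10000 nM in this assay, at which 1 of the 4 values shown sits.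

The ring size and the fluorines enter together here, so their shares stay unseparated, and plain cyclohexyl would divide them. Going by these compounds, whether an open chain such as isopropyl or a ring amine such as piperidine keeps a low number at this carbonyl carbon also remains open.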